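The compounds below may be only part of what the source reports. "The series", "measured", "known", "first", "only" and "open" are said of these compounds alone.

Three compounds have been measured in a functional assay on MC-38 cells (Mus musculus) for antiproliferative activity, read by CCK-8 assay, with a stated time of 48 h (on this read-out higher numbers stand for weaker inhibition and lower numbers for stronger inhibition), and each value is a limit of the assay rather than a number:

Compound 1 `COc1ccc(/C=C\c2cc(OC)c(OC)c(OC)c2)cc1OCc1ccc(CN2C[C@H](O)C[C@@H]2C(=O)O)cc1`: > 10000 nM
Compound 2 `COc1ccc(/C=C\c2cc(OC)c(OC)c(OC)c2)cc1OCc1ccc(CN[C@H](C(=O)O)[C@H](C)O)cc1`: > 10000 nM
Compound 3 `COc1ccc(/C=C\c2cc(OC)c(OC)c(OC)c2)cc1OCc1ccc(CN2CC[C@H](C(=O)O)C2)cc1`: > 10000 nM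

Compound 3 therefore has no number of its own, only the limit it shares with compound 1 and compound 2. The next compound, compound 4 `COc1ccc(/C=C\c2cc(OC)c(OC)c(OC)c2)cc1OCc1ccc(CN2CC[C@@H](O)C2)cc1`, follows from compound 3 by one exchange: 3-hydroxypyrrolidin-1-yl in place of 3-carboxypyrrolidin-1-yl on a saturated chain carbon bound to an aromatic carbon. Here 3-hydroxypyrrolidin-1-yl stands in place of 3-carboxypyrrolidin-1-yl on a saturated chain carbon bound to an aromatic carbon.

The measured steps closest to this change are a step that the two limits leave unreadable from compound 1 to compound 3 and a step that the two limits leave unreadable from compound 2 to compound 3. Neither gives a size to carry over. All three measured compounds carry a carboxy group in this part of the molecule, and all stand at the limit of > 10000 nM in this assay, at which 3 of the 3 values shown sit. Among the compounds with values here, compound 4 is the one without that group, so a move towards stronger inhibition is expected, on this thin ground alone. The expected change is an at least 2.5-fold lower number from compound 3 to compound 4 (0.39 log units; beyond the scatter), and its size is a loose estimate. A further reading at the limit remains possible. For compound 4 the estimated value is 4000 nM, with an expected range from 500 nM to 20000 nM.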

Compound 4, half-maximal inhibitory concentration: 6900 nM
Compound 4: middle estimate off by 1.7-fold (0.24 log units), on the low side; low and high end bracket the measured number.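

In this assay compound 4 is the only compound shown that gives a number rather than a limit, and it is also the only one with no carboxy group on the saturated chain carbon's ring or chain, while the carboxy-bearing compounds all stay at the limit: the limit of > 10000 nM in this assay, at which 3 of the 4 values shown sit.

Exchanging 3-carboxypyrrolidin-1-yl for 3-hydroxypyrrolidin-1-yl gives an at least 1.4-fold lower number from compound 3 to compound 4 (0.16 log units; that floor lies within the scatter), and exchanging (1-carboxy-2-hydroxypropyl)amino for the same group gives an at least 1.4-fold lower number from compound 2 to compound 4 (0.16 log units; that floor lies within the scatter). The most telling comparison is an at least 1.4-fold lower number from compound 1 to compound 4 (0.16 log units; that floor lies within the scatter). There the hydroxy group is present on both sides and only the carboxy group gives way to hydrogen. Compound 1 carries a hydroxy group and still has no readable number. All three steps are floors rather than sizes, and the steps among compound 1, compound 2 and compound 3 cannot be read.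

On these data alone, the true size of the step stays open, as does whether the hydroxy group of compound 4 contributes anything beyond the absence of the carboxy group. An unsubstituted pyrrolidin-1-yl, a piperidin-1-yl or a 3-aminopyrrolidin-1-yl on the same saturated chain carbon would bear on that question.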